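Fluorine on the phenyl of a thioether side chain

A few compounds are considered here, and "the series" means these few. Any claim that something is new, unique, unknown or untested is made for them only; others in the source may bear on it.

Three compounds have been measured in an assay on isolated protein for inhibition of retinal dehydrogenase 2 (Homo sapiens); a higher number here means a weaker inhibitor, a lower number a stronger inhibitor:

Compound 1 `CC(C)C(Sc1nc2c(cnn2C)c(=O)n1-c1ccccc1)c1ccccc1` gives 300 nM in this assay.
Compound 2 `CC(Sc1nc2nn(CC3COC3)cc2c(=O)n1-c1ccccc1)c1ccccc1` gives 80 nM in this assay.
Compound 3 `C[C@@H](Sc1nc2c(cnn2C)c(=O)n1-c1ccccc1)c1ccccc1` gives 40 nM in this assay.

Compound 3 has the lowest of the three numbers. Its nearest neighbour is compound 2, whose value lies within the scatter of compound 3, so nothing can be said about an order between these two. Compound 1 sits furthest away, with a number beyond the scatter of compound 3.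

Compound 4 `CC(Sc1nc2c(cnn2C)c(=O)n1-c1ccccc1)c1cccc(F)c1` has not yet been measured. It differs from compound 3 in one place: 1-(3-fluorophenyl)ethyl in place of 1-phenylethyl on a sulfur. The rest of the molecule, the shared core and its attached phenyl, is kept.

Among the compounds with values here, no measured pair in this set shows what a single fluorine on this ring does, so the expectation for compound 4 rests on the starting point alone. A change of this small size, which keeps the donor and acceptor count unchanged, is expected to move the number little in this assay, most likely no further than the scatter and in no firm direction. For compound 4 the expected step is a 1.1-fold lower number from compound 3 to compound 4 (0.06 log units; within the scatter). Compound 4 is therefore estimated at 35 nM, within a range from 15 nM to 100 nM.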

Compound 4, half-maximal inhibitory concentration: 110 nM
Compound 4: the middle estimate sits 3.1-fold (0.50 log units) below what was measured, and the stated range ends below it.
By their numbers in this assay, from the lowest: compounds 3, 2 and 4 (each within the scatter of the next, the first and the last beyond it); then compound 1.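

In this assay, putting 1-(3-fluorophenyl)ethyl in place of 1-phenylethyl on a sulfur gives a 2.8-fold higher number from compound 3 to compound 4 (0.44 log units; beyond the scatter), a modest step. It shows that the number at this position can move beyond the scatter even when the change leaves the hydrogen-bond donor and acceptor counts as they were. The step is not a clean reading of fluorine alone, however: the leaving 1-phenylethyl has a defined stereocentre, the entering group has none, and no information is available to explain the step or divide it between these two differences.

Going by these compounds, it remains open whether 1-(3-fluorophenyl)ethyl with a defined stereocentre would give a number closer to that of compound 3, which would separate the contribution of fluorine from that of the stereocentre. A single step also cannot say how this position responds to other groups on the ring, such as 1-(3-chlorophenyl)ethyl or 1-(3-methoxyphenyl)ethyl, or whether the higher number seen here is particular to fluorine.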